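From compound 2 to compound 4: fluoro for bromo

This account rests on a few compounds, and the source may have more. Where it says the series, first, only, none or still open, it means among the compounds named here.

In a functional assay on NCI-H292 cells (Homo sapiens) for cytotoxicity, read by MTT assay, with a stated time of 72 h, tested at 10 ug/mL (a higher number here means more inhibition of growth at the concentration tested, a lower number less inhibition of growth), compound 2 (`O=C1NC(=S)/C(=C/c2ccc(Br)cc2)S1`) gives 36.5%, within the scatter of both compound 1 (`O=C1NC(=S)/C(=C/c2ccc(Cl)cc2)S1`) at 41.4% and compound 3 (`O=C1NC(=S)/C(=C/c2cccc(F)c2)S1`) at 26.8%. Compound 4 (`O=C1NC(=S)/C(=C/c2ccc(F)cc2)S1`) carries fluoro in place of bromo on an aromatic carbon. Among the measured compounds shown here, the only measured step bearing on this change is a swap of one such group for another, a number 4.9 percentage points lower from compound 1 to compound 2 (within the scatter), which stays within the scatter. For the measured compounds named here, compound 3 is the only measured fluoro compound, and its 26.8% leans the expectation slightly downward. The expected step is small, lower and within the scatter: a number 5.5 percentage points lower from compound 2 to compound 4 (within the scatter). For compound 4 the estimated value is 31%, with an expected range from 17% to 45%.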

Compound 4, percent growth inhibition at one concentration: 38%
For compound 4 the middle estimate is 7 percentage points below the measured one, and the stated range covers the measured number.
By their numbers in this assay, from the lowest: compounds 3, 2, 4 and 1 (each within the scatter of the next, the first and the last beyond it).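

Fluoro in the position para to a group of 8 heavy atoms gives a number 1.5 percentage points higher from compound 2 to compound 4 (within the scatter) and a number 3.4 percentage points lower from compound 1 to compound 4 (within the scatter) in this assay, with no step beyond the scatter. Chloro, bromo and fluoro at this position therefore cannot be told apart in these compounds, which the single chloro-to-bromo step could not show for fluoro. No evidence bears on the reason for this result.

Still open, as far as these compounds go, is whether an amine, a methoxy group or a carboxylic acid at this position would move growth inhibition beyond the scatter of these halogen compounds.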